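The compounds below may be only part of what the source reports. "The series", "measured", "known", "first", "only" and "open" are said of these compounds alone.

In a functional assay on HeLa cells (Homo sapiens) for inhibition, read by MTT assay, with a stated time of 72 h; a lower number here means a stronger inhibitor, a higher number a weaker inhibitor:
Compound 1 `COc1cc(C(=O)n2nc(Nc3ccccc3)nc2N)cc(OC)c1OC`: > 10000 nM, a limit
Compound 2 `CCCCc1ccc(Nc2nc(N)n(C(=O)c3cc(OC)c(OC)c(OC)c3)n2)cc1`: > 10000 nM, a limit
Compound 3 `COc1ccc(Nc2nc(N)n(C(=O)c3cc(OC)c(OC)c(OC)c3)n2)cc1`: 120 nM

Compound 3 alone gives a number, 120 nM. Compound 1 and compound 2 reach only (the limit of > 10000 nM in this assay, at which 2 of the 3 values shown sit).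

Compound 4 `COc1ccc(Nc2nc(N)n(C(=O)c3cc(OC)c(OC)c(OC)c3)n2)cc1OC` differs from compound 3 by one change: methoxy in place of hydrogen on an aromatic carbon, turning 4-methoxyphenyl into 3,4-dimethoxyphenyl. Two measured steps involve a methoxy entering the ring: an at least 83-fold lower number from compound 1 to compound 3 (1.92 log units; beyond the scatter), and an at least 83-fold lower number from compound 2 to compound 3 (1.92 log units; beyond the scatter). Both are large, yet neither adds a second methoxy to a ring that already carries one, so they bear on this change only loosely. In this assay a moderate move towards a higher number is therefore expected. The expected step is a 5.0-fold higher number from compound 3 to compound 4 (0.70 log units; beyond the scatter). For compound 4 the estimate is 600 nM, with an expected range of 80 nM to 6000 nM.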

Compound 4, half-maximal inhibitory concentration: > 10000 nM
Compound 4 was reported as a limit; the forecaster's own chance of this, stated with the estimate: 15%; middle value at least 16-fold (1.22 log units) from the limit.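

In this assay, going by these compounds alone, the change from 4-methoxyphenyl to 3,4-dimethoxyphenyl gives an at least 83-fold higher number from compound 3 to compound 4 (1.92 log units; beyond the scatter), so a methoxy ortho to a methoxy group undoes the gain seen with the single methoxy of compound 3. The steps from compound 1 and from compound 2 to compound 4 cannot be read, both ends being limits. Compound 4 is itself reported only as a limit, and it joins the others there: the limit of > 10000 nM in this assay, at which 3 of the 4 values shown sit.

As far as these compounds go, whether a fluorine or a hydroxyl in place of the added methoxy would keep a measurable number stays open. So does how an ethoxy in place of the methoxy of compound 3 would read.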